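Sulfonyl aryl ring: fluoro to ethyl

The compounds below may be only part of what the source reports. "The series", "measured", "known", "first", "only" and "open" are said of these compounds alone.

For the measured compounds named here, compound 2 `Nc1cc(S(=O)(=O)c2ccccc2F)c([N+](=O)[O-])c2cccnc12` gives the lowest number of the two measured so far in an assay for binding affinity to Neuropeptide Y receptor type 1 (Homo sapiens), read by radioligand binding (a higher number here means a weaker inhibitor, a lower number a stronger inhibitor), 58 nM; compound 1 `COc1ccc(S(=O)(=O)c2cc(N)c3ncccc3c2[N+](=O)[O-])cc1` gives 1140 nM, and the only measured step, a 20-fold lower number from compound 1 to compound 2 (1.29 log units; beyond the scatter), came with 2-fluorophenyl in place of 4-methoxyphenyl on a sulfonyl sulfur. Compound 3 `CCc1ccccc1S(=O)(=O)c1cc(N)c2ncccc2c1[N+](=O)[O-]` differs from compound 2 by ethyl in place of fluoro on an aromatic carbon, ortho to a large group. Going by the values given here, no measured step alters this position, so the step of a 20-fold lower number from compound 1 to compound 2 (1.29 log units; beyond the scatter) bears only loosely on it. The step of a 1.4-fold higher number from compound 2 to compound 3 (0.14 log units; within the scatter) is expected to be small, in either direction. Estimate for compound 3 in this assay: 80 nM, range 20 nM to 350 nM.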

Compound 3, inhibition constant: 129 nM
Compound 3: middle estimate off by 1.6-fold (0.21 log units), on the low side; the measured number falls inside the stated range.
By their numbers in this assay, from the lowest: compound 2; then compound 3; then compound 1.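

This position now has a measured step of its own: in this assay the change from 2-fluorophenyl to 2-ethylphenyl gives a 2.2-fold higher number from compound 2 to compound 3 (0.35 log units; beyond the scatter), modest but beyond the scatter. With ethyl in place of fluoro, the series still holds a clear advantage over the 4-methoxyphenyl compound, with an 8.8-fold lower number from compound 1 to compound 3 (0.95 log units; beyond the scatter). No available evidence accounts for the difference between fluoro and ethyl here.

Still open, on these data alone, is where a chloro or methyl group at this position would fall relative to fluoro and ethyl. A longer chain or an amine here also remains untested in the compounds shown.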